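This account rests on a few compounds, and the source may have more. Where it says the series, first, only, none or still open, it means among the compounds named here.

Measured in a functional assay on the whole organism (strain Sprague-Dawley) for inhibition, with Rattus norvegicus as the target, with a stated time of 10 min; on this read-out higher numbers stand for an effect only at larger amounts of compound and lower numbers for an effect already at smaller amounts:
- compound 1 `COc1ccccc1-c1ncc(C(=O)O)c(=O)[nH]1`: 10 mg/kg
- compound 2 `CC(C)COc1ccccc1-c1ncc(C(=O)O)c(=O)[nH]1`: 0.5 mg/kg
- compound 3 `C=CCOc1ccccc1-c1ncc(C(=O)O)c(=O)[nH]1`: 0.5 mg/kg

Compound 3 shares the lowest of the three numbers with compound 2: no change at the digits printed from compound 2 to compound 3 (within the scatter). The next structure, compound 4 `CSc1ccccc1-c1ncc(C(=O)O)c(=O)[nH]1`, differs as follows: methylsulfanyl in place of allyloxy on an aromatic carbon. For the measured compounds named here, no measured compound carries sulfur, so the evidence is indirect. The closest guides are a 20-fold lower number from compound 1 to compound 3 (1.30 log units; beyond the scatter) and a 20-fold lower number from compound 1 to compound 2 (1.30 log units; beyond the scatter), both large and both tied to extending the short methoxy chain of compound 1. The short methylsulfanyl drops that extension, so most of this gain is expected to be lost in this assay. The expected change is a 10-fold higher number from compound 3 to compound 4 (1.00 log units; beyond the scatter), towards a higher number. The estimate for compound 4 is 5 mg/kg, with an expected range of 1 mg/kg to 20 mg/kg.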

Compound 4, dose for 50% inhibition: > 20 mg/kg
Compound 4: a limit, no number (the forecaster's own chance of this, stated with the estimate: 10%); middle value at least 4.0-fold (0.60 log units) away from the limit.
By their numbers in this assay, from the lowest: compounds 2 and 3 (each within the scatter of the next); then compound 1. At a limit, above all of these: compound 4.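

Compound 4 gives > 20 mg/kg in this assay, a limit of the assay and not a number: the limit of > 20 mg/kg in this assay, at which 1 of the 4 values shown sits. On this aromatic carbon, ortho to a large group, methylsulfanyl gives up the gain of the longer ethers, with an at least 40-fold higher number from compound 3 to compound 4 (1.60 log units; beyond the scatter) and an at least 40-fold higher number from compound 2 to compound 4 (1.60 log units; beyond the scatter). Against the methoxy group the reading is an at least 2.0-fold higher number from compound 1 to compound 4 (0.30 log units; that floor lies within the scatter), so these two short groups are not separated.

Still open, as far as these compounds go, is whether the sulfur or the short chain accounts for the loss. A longer chain on sulfur, such as allylsulfanyl, would separate the two.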